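The source may report more compounds than this note shows. Statements on the series, on what has been measured and on what is new or still open speak of the compounds shown alone.

Of the compounds shown here, three built on one shared core have been tested in a functional assay on UACC-62 cells (Homo sapiens) for cytotoxicity, read by sulforhodamine B assay; on this read-out lower numbers stand for stronger inhibition of growth and higher numbers for weaker inhibition of growth. Compound 1 `CC1=CC[C@@H]([C@@](C)(O)CCCC(C)(C)NC(=S)N/N=C\c2ccc(C)cc2)CC1` gives 11600 nM. Compound 2 `CC1=CC[C@@H]([C@@](C)(O)CCCC(C)(C)NC(=S)N/N=C\c2ccc(O)cc2)CC1` gives in this assay 8870 nM, and compound 3 `CC1=CC[C@@H]([C@@](C)(O)CCCC(C)(C)NC(=S)N/N=C\c2ccc(Cl)cc2)CC1` gives 7350 nM. The moves among them are all small: a 1.3-fold lower number from compound 1 to compound 2 (0.12 log units; within the scatter), a 1.6-fold lower number from compound 1 to compound 3 (0.20 log units; within the scatter) and a 1.2-fold lower number from compound 2 to compound 3 (0.08 log units; within the scatter). Compound 3 thus shows the lowest of the three numbers, but its gap to compound 2 and to compound 1 sits within the scatter, so no order among the three can be read from these values.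

Compound 4 `CC1=CC[C@@H]([C@@](C)(O)CCCC(C)(C)NC(=S)N/N=C(/C)c2ccccc2)CC1` has not yet been measured. Compared with compound 3 the change is a group of 9 heavy atoms (8 carbon, 1 nitrogen; one six-membered aromatic ring of carbon only) in place of a group of 9 heavy atoms (7 carbon, 1 nitrogen, 1 chlorine; one six-membered aromatic ring of carbon only), on an amide-type nitrogen. None of the three measured steps touches this part of the molecule; each of them exchanged one group on the aromatic ring, and each stayed within the scatter. There is therefore no measured basis for expecting a large move in this assay in either direction, and the estimate for compound 4 is drawn from the narrow band of the three known values. The step of a 1.2-fold higher number from compound 3 to compound 4 (0.06 log units; within the scatter) is expected to remain within the scatter. For compound 4 the expected value in this assay is 8500 nM, with a range from 3000 nM to 24000 nM.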

Compound 4, concentration for 50% growth inhibition: 22400 nM
Estimate against measurement, compound 4: 2.6-fold (0.42 log units) below; measured number inside the range.
By their numbers in this assay, from the lowest: compounds 3, 2, 1 and 4 (each within the scatter of the next, the first and the last beyond it).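

In this assay, for the compounds shown here, exchanging the whole group on the amide-type nitrogen gives the first steps that pass beyond the scatter, with a 3.0-fold higher number from compound 3 to compound 4 (0.48 log units; beyond the scatter) and a 2.5-fold higher number from compound 2 to compound 4 (0.40 log units; beyond the scatter) both modest in size, whereas the earlier swaps of one group on the aromatic ring all stayed within it. The exchange does not set compound 4 apart from every other compound, since a 1.9-fold higher number from compound 1 to compound 4 (0.29 log units; within the scatter) stays within the scatter even though this is also a change of the group at this position, so compound 4 differs clearly only from compound 2 and compound 3. Nothing in the available data gives a reason for these shifts.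

The compounds shown leave open whether the higher number belongs to this one group or would extend to other groups on the amide-type nitrogen, such as one with a longer chain in place of the group in compound 4. They also leave open how an amine or a carboxylic acid on the aromatic ring of that group would read in this assay.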